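The source may hold more compounds than are shown below. What is called first, only, known or untested is meant among the compounds shown, and "the series" means these compounds.

Measured so far:
- compound 1, `O=C(Nc1ccc(Oc2ccnc3[nH]ccc23)cc1)c1nn(-c2ccc(Cl)cc2)ccc1=O`: 10600 nM
- compound 2, `O=C(Nc1ccc(Oc2ccnc3[nH]ccc23)c(F)c1)c1nn(-c2ccc(Br)cc2)ccc1=O`: 11600 nM
- compound 3, `Cn1ccc2c(Oc3ccc(NC(=O)c4nn(-c5ccc(Cl)cc5)ccc4=O)cc3)ccnc21`: > 60000 nM

In a functional assay on MCF7 cells (Homo sapiens) for cytotoxicity, read by MTT assay, with a stated time of 72 h (a lower number here means a stronger inhibitor, a higher number a weaker inhibitor), compound 1 gives 10600 nM. Going by the values given here, compound 2 gives 11600 nM in this assay; no single-place step is computed between these two, and their values show no separation. For compound 3 this assay reports only a limit, > 60000 nM, so no number is known for it. That limit is the limit of > 60000 nM in this assay, at which 1 of the 3 values shown sits. The one measured step, an at least 5.6-fold higher number from compound 1 to compound 3 (0.75 log units; beyond the scatter), places compound 3 at the weak end of what is shown.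

Compound 4, `Cn1ccc2c(Oc3ccc(NC(=O)c4nn(-c5ccc(Br)cc5)ccc4=O)cc3)ccnc21`, differs from compound 3 by bromo in place of chloro on an aromatic carbon. Among the compounds with values here, no measured step covers that change on its own; compounds 1 and 2 carry it together with a second alteration. Compound 4 is therefore expected to remain near the same limit, with a step that the limit leaves unreadable from compound 3 to compound 4. The estimate for compound 4 is 80000 nM, between 40000 nM and 200000 nM.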

Compound 4, half-maximal inhibitory concentration: 16300 nM
Estimate against measurement, compound 4: 4.9-fold (0.69 log units) above; the whole stated range lies above it.
By their numbers in this assay, from the lowest: compounds 1, 2 and 4 (each within the scatter of the next). At a limit, above all of these: compound 3.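

In this assay, the change from 4-chlorophenyl to 4-bromophenyl, now seen on its own with the methyl on the aromatic nitrogen kept, gives an at least 3.6-fold lower number from compound 3 to compound 4 (0.56 log units; beyond the scatter). A single halogen swap at this place can therefore move the number beyond the scatter. On these data alone, compound 3 stands only at a limit, so the true size of the step stays unknown: the limit of > 60000 nM in this assay, at which 1 of the 4 values shown sits.

As far as these compounds go, whether the same swap matters with hydrogen on that nitrogen stays open. So does what iodo, methoxy or an amine would give at this place.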